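This account rests on a few compounds, and the source may have more. Where it says the series, first, only, none or still open, it means among the compounds named here.

Measured so far:
Compound 1, `Cc1ccc(-c2cc(C(=O)Nc3nnc(-c4ccncc4)s3)c3ccccc3c2)o1`, gives 25%.
Compound 2, `O=C(Nc1nnc(-c2ccncc2)s1)c1cc(-c2ccco2)cc2ccccc12`, gives 0%.
Compound 3, `Cc1ccc(-c2ccc3ccccc3n2)o1`, gives 102%.

These numbers come from a physicochemical assay for metabolic stability, read by LC-MS, with a stated time of 38 days, tested at 10 mM; on this read-out lower numbers stand for a less stable compound and higher numbers for a more stable compound. Compound 1 and compound 2 differ in one place, (hydrogen in place of methyl on an aromatic carbon), and this assay records a number 25 percentage points lower from compound 1 to compound 2 (beyond the scatter). Compound 4, `c1coc(-c2ccc3ccccc3n2)c1`, is not yet measured; it differs from compound 3 by hydrogen in place of methyl on an aromatic carbon, the same change made on another core. How the core of compound 3 differs from the core of compound 1 is not broken down here. Compound 3 stands highest of the three, and nothing remaining above it can be recorded. Taking the step seen once as a guide, compound 4 is expected to give 88%, between 65% and 105%. That estimate means a number 14 percentage points lower from compound 3 to compound 4 (beyond the scatter), resting only on a number 25 percentage points lower from compound 1 to compound 2 (beyond the scatter) and on compound 3 giving 102%.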

Compound 4, percent of the compound remaining: 117%
Beside the measured number, compound 4's estimate is 29 percentage points below it; measured number above the stated range.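

In this assay the same change, hydrogen in place of methyl on an aromatic carbon, gives a number 25 percentage points lower from compound 1 to compound 2 (beyond the scatter) on one core but a number 15 percentage points higher from compound 3 to compound 4 (beyond the scatter) on the other, so the two steps run in opposite directions. The size and direction of this change therefore did not carry from one core to the other, although two steps cannot show which direction would hold on further cores. Nothing available here explains the difference between the two cores.

On these data alone, it remains open whether an ethyl group, an amine or a carboxylic acid in that same place would raise or lower the number on either core. As far as these compounds go, it also remains open whether a further core would follow compound 1 and compound 2 or compound 3 and compound 4.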